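Changing the side chain of compound 2

The source may report more compounds than this note shows. Statements on the series, on what has been measured and on what is new or still open speak of the compounds shown alone.

In a functional assay on HCT-116 cells (Homo sapiens) for cytotoxicity, read by fluorescence, with a stated time of 72 h (a lower number here means a stronger inhibitor, a higher number a weaker inhibitor), compound 1 `CC(C)c1n[nH]c2c(NCc3ccc(-c4ccccn4)cc3)nc(S(C)(=O)=O)nc12` gives 1140 nM and compound 2 `CC(C)c1n[nH]c2c(NCc3ccc(-c4ccccn4)cc3)nc(NCC(N)CO)nc12` gives 781 nM. These two numbers lie within the scatter of each other, so compound 2 stands level with compound 1 on the only data available.

Compound 3 `CC(C)c1n[nH]c2c(NCc3ccc(-c4ccccn4)cc3)nc(NCCN(C)C)nc12` keeps the core of compound 2 and alters only its side chain: (dimethylamino)methyl in place of 1-amino-2-hydroxyethyl on a saturated chain carbon bound to a nitrogen on an aromatic ring. In words, (dimethylamino)methyl sits in place of 1-amino-2-hydroxyethyl on a saturated chain carbon bound to a nitrogen on an aromatic ring.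

Just one measured step bears on this, and only indirectly. It is a 1.5-fold lower number from compound 1 to compound 2 (0.16 log units; within the scatter), which replaced a whole group on an aromatic carbon and stayed within the scatter. Within the data shown here, no measured step changes the chain itself, so this is weak guidance. Nothing in these data points to a step beyond the scatter in this assay. The expected step is a 1.0-fold lower number from compound 2 to compound 3 (0.02 log units; within the scatter). For compound 3 the estimated value is 750 nM, with an expected range from 270 nM to 2100 nM.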

Compound 3, half-maximal inhibitory concentration: 390 nM
Estimate against measurement, compound 3: 1.9-fold (0.28 log units) above; the measured number falls inside the stated range.
By their numbers in this assay, from the lowest: compounds 3, 2 and 1 (each within the scatter of the next, the first and the last beyond it).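

In this assay, the change on the saturated chain carbon takes out 1-amino-2-hydroxyethyl, with 2 hydrogen-bond donors, and puts in (dimethylamino)methyl, with 0 hydrogen-bond donors, and it gives a 2.0-fold lower number from compound 2 to compound 3 (0.30 log units; within the scatter). So this position accepts a real change in the side chain, and the count of hydrogen-bond donors can go from 2 to 0 with no shift beyond the usual scatter. Among these compounds, the wider swap on the aromatic carbon, (2-(dimethylamino)ethyl)amino in place of methylsulfonyl, gives a 2.9-fold lower number from compound 1 to compound 3 (0.47 log units; beyond the scatter), which makes it the first step in this small set to pass beyond the scatter, though only modestly. Nothing measured here explains why the numbers fall as they do.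

Going by these compounds, it remains open how this position would respond to a longer chain, to a ring amine such as morpholine or piperidine, or to a carboxylic acid at the end of the chain. Also open, on these data alone, is what a chain carrying only the amine or only the hydroxyl of 2-amino-3-hydroxypropyl would give, since here the two leave together.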